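Cyclopropyl in place of thiophen-2-yl: a small expected step

The source may hold more compounds than are shown below. What is called first, only, known or untested is meant among the compounds shown, and "the series" means these compounds.

In a functional assay on the whole organism with Mus musculus as the target (on this read-out higher numbers stand for an effect only at larger amounts of compound and lower numbers for an effect already at smaller amounts), compound 1 (`C[C@@H](NCc1ccc(Oc2ccccc2)cc1)C(N)=O`) gives 64 mg/kg, compound 2 (`C[C@@H](NCc1ccc(OCc2ccc(F)cc2)cc1)C(N)=O`) gives 132 mg/kg and compound 3 (`C[C@@H](NCc1ccc(OCc2cccs2)cc1)C(N)=O`) gives 61.6 mg/kg. Compound 3 thus shares the low end of these numbers with compound 1. Compound 4 (`C[C@@H](NCc1ccc(OCC2CC2)cc1)C(N)=O`) carries cyclopropyl in place of thiophen-2-yl on a saturated chain carbon bound to an oxygen on an aromatic ring. For the measured compounds named here, two measured steps bear on this change: there is a 1.0-fold lower number from compound 1 to compound 3 (0.02 log units; within the scatter), and a 2.1-fold lower number from compound 2 to compound 3 (0.33 log units; beyond the scatter). Neither is large, so no clear change is expected in this assay, and the estimated step is a 1.2-fold higher number from compound 3 to compound 4 (0.09 log units; within the scatter). Compound 4 is estimated at 75 mg/kg, with an expected range from 38 mg/kg to 150 mg/kg.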

Compound 4, dose for half-maximal effect: 124 mg/kg
Estimate against measurement, compound 4: 1.7-fold (0.22 log units) below; low and high end bracket the measured number.
By their numbers in this assay, from the lowest: compounds 3, 1, 4 and 2 (each within the scatter of the next, the first and the last beyond it).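

In this assay, for the compounds shown here, the earlier compounds carried only aromatic rings at this place, while compound 4 shows the effect of a non-aromatic ring of carbon only. All three new steps stay within the scatter: a 2.0-fold higher number from compound 3 to compound 4 (0.30 log units; within the scatter), a 1.1-fold lower number from compound 2 to compound 4 (0.03 log units; within the scatter) and a 1.9-fold higher number from compound 1 to compound 4 (0.29 log units; within the scatter). Compound 4 therefore does not separate from any of the other compounds, even though compound 2 and compound 3 lie beyond the scatter of each other. Nothing available explains these steps. On these data alone, whether an amine or a longer chain in place of cyclopropyl would give a step beyond the scatter remains open.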